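The source may report more compounds than this note shows. Statements on the series, on what has been measured and on what is new or still open speak of the compounds shown alone.

Compound 3 `CCc1ccc(C(=O)Nc2cccc(-c3oc4cc(-c5ccc(F)cc5)ccc4c(=O)c3O)c2)cc1` carries a 4-ethylphenyl group at one end of the shared core. In a functional assay on MCF7 cells (Homo sapiens) for antiproliferative activity, read by CCK-8 assay, with a stated time of 72 h (a lower number here means a stronger inhibitor, a higher number a weaker inhibitor), compound 3 gives 22800 nM. Its two measured neighbours differ from it only at the same aromatic carbon: compound 1 `O=C(Nc1cccc(-c2oc3cc(-c4ccc(F)cc4)ccc3c(=O)c2O)c1)c1ccc(C(F)(F)F)cc1` carries trifluoromethyl there and gives 32600 nM, while compound 2 `O=C(Nc1cccc(-c2oc3cc(-c4ccc(F)cc4)ccc3c(=O)c2O)c1)c1ccc(Br)cc1` carries bromo and gives 24000 nM. The steps of a 1.4-fold lower number from compound 1 to compound 3 (0.16 log units; within the scatter) and a 1.1-fold lower number from compound 2 to compound 3 (0.02 log units; within the scatter) both stay within the scatter, and the step of a 1.4-fold lower number from compound 1 to compound 2 (0.13 log units; within the scatter) does the same, so the three groups tried so far at this position leave the numbers indistinguishable from one another.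

Compound 4 `N#Cc1ccc(C(=O)Nc2cccc(-c3oc4cc(-c5ccc(F)cc5)ccc4c(=O)c3O)c2)cc1` continues this short series: cyano in place of ethyl on an aromatic carbon. Among the measured compounds shown here, every step recorded at this position has been within the scatter, so the only guide available is that the site has so far accepted a change of group without moving the number. For the measured compounds named here, no measured pair involves cyano, so the expectation rests on that record alone. Compound 4 is therefore expected to give a value close to those of its neighbours, with the step of a 1.1-fold higher number from compound 3 to compound 4 (0.04 log units; within the scatter) expected to lie within the scatter. The estimate for compound 4 in this assay is 25000 nM, with a likely range from 10000 nM to 60000 nM.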

Compound 4, half-maximal inhibitory concentration: 2660 nM
Estimate against measurement, compound 4: 9.4-fold (0.97 log units) above, and the stated range ends above it.
By their numbers in this assay, from the lowest: compound 4; then compounds 3, 2 and 1 (each within the scatter of the next).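

In this assay, among the compounds shown here, cyano is the first group at this position to move the number beyond the scatter, with an 8.6-fold lower number from compound 3 to compound 4 (0.93 log units; beyond the scatter) and with a 9.0-fold lower number from compound 2 to compound 4 (0.96 log units; beyond the scatter) as well as a 12-fold lower number from compound 1 to compound 4 (1.09 log units; beyond the scatter) against the other two groups. The position para to a large group is therefore not indifferent to what it carries: ethyl, bromo and trifluoromethyl sit within the scatter of one another, while cyano stands clearly apart from all three, even though the swap from ethyl keeps the same number of heavy atoms and adds one triple bond and one hydrogen-bond acceptor. Nothing among the data shown accounts for why cyano behaves differently from the other three groups.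

Four groups cannot show whether this drop belongs to cyano alone or would also appear with an acetyl group, a carboxylic acid, a methoxy group or an amine at the same ring carbon. From the compounds shown here alone, it also remains open whether moving the cyano group to another carbon of that ring would keep compound 4 at 2660 nM or return the number to the level of the other three compounds.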